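A Fluoro-for-Methyl Swap Tested for Cell Killing

The compounds below may be only part of what the source reports. "The series", "measured", "known", "first", "only" and "open" are said of these compounds alone.

Compound 2 `Cc1cn(C2[Se][C@H](CO)[C@@H](O)[C@@H]2N=[N+]=[N-])c(=O)[nH]c1=O` was tested in a functional assay on HCT-116 cells (Homo sapiens) for cytotoxicity, read by sulforhodamine B assay; a higher number here means a weaker inhibitor, a lower number a stronger inhibitor. In this assay compound 2 gives only a limit of > 100000 nM. Compound 1 `[N-]=[N+]=N[C@@H]1C(n2ccc(=O)[nH]c2=O)[Se][C@H](CO)[C@H]1O` carries a hydrogen where compound 2 carries a methyl. In this assay compound 1 also gives only a limit of > 100000 nM. The step that the two limits leave unreadable from compound 1 to compound 2 is unreadable because both values sit at the limit of > 100000 nM in this assay, at which 2 of the 2 values shown sit.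

Compound 3 `[N-]=[N+]=N[C@@H]1C(n2cc(F)c(=O)[nH]c2=O)[Se][C@H](CO)[C@H]1O` arises from compound 2 by fluoro in place of methyl on an aromatic carbon. Within the data shown here, no measured step reports a readable size for such a swap. Compound 3 is expected to stay at the limit, estimated at 150000 nM with a range of 30000 nM to 600000 nM. The expected step that the limit leaves unreadable from compound 2 to compound 3 is therefore nothing beyond the scatter.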

Compound 3, half-maximal inhibitory concentration: > 100000 nM
Compound 3: a limit, no number; the forecaster's own chance of this, stated with the estimate: 85%; the middle value does not contradict the limit.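

The steps among compound 1, compound 2 and compound 3 cannot be read, because each compound gives only a limit, not a number: the limit of > 100000 nM in this assay, at which 3 of the 3 values shown sit.

Going by these compounds, how hydrogen, methyl and fluoro on that aromatic carbon compare in strength stays open.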